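Amino in Place of Chloro: Expectation for Compound 3

A few compounds are considered here, and "the series" means these few. Any claim that something is new, unique, unknown or untested is made for them only; others in the source may bear on it.

Measured compounds:
compound 1, `ClCc1ccccc1Cn1cnc2c(Cl)nc(Cl)nc21`: 5620 nM
compound 2, `ClCc1cccc(Cn2cnc3ncnc(Cl)c32)c1`: "not determined" (no result reported)

In a functional assay on SF-539 cells (Homo sapiens) for cytotoxicity, read by sulforhodamine B assay, with a stated time of 48 h (on this read-out lower numbers stand for higher toxicity in this test and higher numbers for lower toxicity in this test), compound 1 gives 5620 nM. Within the data shown here, this is the only number in the set, as compound 2 shows "not determined" (no result reported), so compound 1 cannot be ranked against any other compound here. Compound 3, `Nc1nc(Cl)c2ncn(Cc3ccccc3CCl)c2n1`, has yet to be measured. It differs from compound 1 in one place: amino in place of chloro on an aromatic carbon. Among the measured compounds shown here, there is no step between two measured compounds to lean on, so the expectation rests on compound 1 alone. The change is expected to move the read-out only modestly, if at all, leaning toward lower toxicity, and the step is estimated as a 1.4-fold higher number from compound 1 to compound 3 (0.15 log units; within the scatter), close to the usual scatter. Compound 3 is therefore expected to give about 8000 nM in this assay, with a range from 2500 nM to 25000 nM.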

Compound 3, concentration lethal to 50% of the cells: 81300 nM
Beside the measured number, compound 3's estimate is 10-fold (1.01 log units) below it; measured number above the stated range.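

In this assay, amino in place of chloro on the aromatic carbon between two ring nitrogen atoms gives a 14-fold higher number from compound 1 to compound 3 (1.16 log units; beyond the scatter), a large step toward lower toxicity in this test. Among these compounds, this is the first reading at this position, and it shows that the read-out is sensitive there: exchanging one heavy atom for one other, with one hydrogen-bond donor and one hydrogen-bond acceptor added by count, is enough to produce a step of this size. No measured evidence bears on what lies behind the step.

With a single step, the compounds shown cannot separate the effect of losing the chloro group from that of gaining the amino group. As far as these compounds go, it also remains open how a methoxy or a methylamino group on the same carbon would read, and whether the step would hold with another group in place of the remaining chloro group.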